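The compounds below may be only part of what the source reports. "The series", "measured", "known", "first", "only" and "open" are said of these compounds alone.

Compound 3 `Cn1c(-c2ccccc2)cnc1NC(=O)c1ccc(Br)cc1` has been tested in a toxicity assay on THP-1 cells (Homo sapiens) for inhibition; a higher number here means that more compound is tolerated, a lower number that less compound is tolerated. In this assay compound 3 gives only a limit, > 100000 nM, so no number stands for it. Compound 1 `Cn1c(-c2cccc(C#N)c2)cnc1NC(=O)c1ccc(F)cc1` likewise gives a limit in this assay, > 100000 nM. Compound 2 `Cc1cccc(-c2cnc(NC(=O)c3ccc(F)cc3)n2C)c1` also reaches only a limit in this assay, > 100000 nM. Within the data shown here, the single one-place step among the measured compounds, a step that the two limits leave unreadable from compound 1 to compound 2, therefore cannot be sized, because the limit of > 100000 nM in this assay, at which 3 of the 3 values shown sit, holds every value in this set.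

Compound 4 `Cn1c(-c2ccccc2)cnc1NC(=O)c1ccc(F)cc1` is the next compound, not yet measured. It differs from compound 3 by fluoro in place of bromo on an aromatic carbon. Among the measured compounds shown here, no measured step touches this position or this exchange: the step between compound 1 and compound 2 concerns a different ring and is itself unreadable. For the measured compounds named here, the only guidance is that every value so far sits at a limit. Compound 4 is thus expected to show no change beyond the scatter, and its estimated result in this assay is 100000 nM, within a range from 50000 nM to 200000 nM. The expected step of a number no higher from compound 3 to compound 4 (the limit leaves the size open) is therefore essentially flat.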

Compound 4, half-maximal cytotoxic concentration: > 100000 nM
Compound 4 was reported as a limit; the forecaster's own chance of this, stated with the estimate: 85%; the middle value sits exactly at the limit.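

With compound 4 also reported only as a limit in this assay, no step among compound 1, compound 2, compound 3 and compound 4 can be read: the limit of > 100000 nM in this assay, at which 4 of the 4 values shown sit.

The compounds shown leave open at what concentration, if any, each would become toxic to these cells, and whether fluoro in place of bromo alters that concentration.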